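Dimethylamino in Place of Amino on the Aminopyridine

The compounds below may be only part of what the source reports. "The series", "measured", "known", "first", "only" and "open" are said of these compounds alone.

Compound 1: `CN(C)c1ncc(-c2ccc(O)cc2)cc1-c1ccc(S(C)(=O)=O)cc1`, 7940 nM
Compound 2: `CC(C)NC(=O)c1ccc(-c2cnc(N)c(-c3ccc(C#N)cc3)c2)cc1`, 25.1 nM

In an assay on Sf21 cells for inhibition of mitogen-activated protein kinase kinase kinase kinase 4 (Homo sapiens), read by ADP-Glo, with stated times of 30 min and 120 min (a higher number here means a weaker inhibitor, a lower number a stronger inhibitor), compound 2 gives 25.1 nM, the lower of the two numbers shown. The structure of compound 2 differs in several places from that of compound 1; in this assay compound 1 gives a value of 7940 nM, a gap that lies beyond the scatter; with more than one change between them, no single change can be read from that gap.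

Compound 3 is `CC(C)NC(=O)c1ccc(-c2cnc(N(C)C)c(-c3ccc(C#N)cc3)c2)cc1`. It differs from compound 2 in one place: dimethylamino in place of amino on an aromatic carbon. Within the data shown here, no step between measured compounds isolates this change. Compound 1 carries the same dimethylamino group and gives the weaker number, but its other differences leave the effect of this change open. The step from compound 2 to compound 3 is expected to weaken inhibition by a 10-fold higher number from compound 2 to compound 3 (1.00 log units; beyond the scatter), beyond the scatter. Compound 3 is therefore estimated at 250 nM, with a range from 60 nM to 1500 nM.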

Compound 3, half-maximal inhibitory concentration: 50100 nM
For compound 3 the middle estimate is 200-fold (2.30 log units) below the measured one; the measured number lies above the stated range.
By their numbers in this assay, from the lowest: compound 2; then compound 1; then compound 3.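

Taken alone, dimethylamino in place of amino on the aromatic carbon next to the ring nitrogen gives a 2000-fold higher number from compound 2 to compound 3 (3.30 log units; beyond the scatter) in this assay, a large loss of inhibition that compound 1, with its several other differences, could not reveal. This position therefore tolerates this change poorly, although the exchange leaves the ring and the net charge as they were and replaces the single hydrogen-bond donor of amino with none. No measurement shown here bears on the reason for this loss.

From the compounds shown here alone, it remains open whether methylamino, with a single methyl on the nitrogen, would retain the inhibition of compound 2 or share the loss seen with compound 3. Going by these compounds, it also remains open whether the same exchange costs as much when a group other than 4-cyanophenyl stands ortho to this position.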